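The source may report more compounds than this note shows. Statements on the series, on what has been measured and on what is new or still open speak of the compounds shown alone.

Measured so far:
compound 1 `COc1c(OC(C)C)cc2occ(-c3csc4ccccc34)c(=O)c2c1OC(C)C` — 8900 nM
compound 2 `COc1c(OC(C)C)cc2occ(-c3csc4ccccc34)c(=O)c2c1O` — 7200 nM

In a functional assay on A549 cells (Homo sapiens) for antiproliferative activity, read by sulforhodamine B assay, with a stated time of 72 h (a higher number here means a weaker inhibitor, a lower number a stronger inhibitor), compound 2 gives 7200 nM, the lowest of the two numbers shown, though the step of a 1.2-fold lower number from compound 1 to compound 2 (0.09 log units; within the scatter) leaves it within the scatter of compound 1. Compound 3 `COc1c(O)cc2occ(-c3csc4ccccc34)c(=O)c2c1O` is the next step, with hydrogen in place of isopropyl on an oxygen on an aromatic ring. Going by the values given here, the only measured step that bears on it is a 1.2-fold lower number from compound 1 to compound 2 (0.09 log units; within the scatter), the same kind of exchange, and it did not move the number beyond the scatter. The step of a 1.1-fold lower number from compound 2 to compound 3 (0.04 log units; within the scatter) is therefore expected to stay within the scatter as well, with no clear direction. Compound 3 is estimated at 6500 nM, range 2500 nM to 17000 nM.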

Compound 3, half-maximal inhibitory concentration: > 10000 nM
Compound 3 gave a limit, no number (the forecaster's own chance of this, stated with the estimate: 2%); middle value at least 1.5-fold (0.18 log units) away from the limit.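

In this assay, the exchange of the remaining isopropoxy to hydroxy reads as an at least 1.3-fold higher number from compound 2 to compound 3 (0.14 log units; that floor lies within the scatter). The result for compound 3 is a limit, not a number: the limit of > 10000 nM in this assay, at which 1 of the 3 values shown sits.

Unlike the earlier isopropoxy to hydroxy exchange, this step has only a floor, so a rise beyond the scatter is possible but not shown. On these data alone, the true size of this step stays open. So does the effect on this oxygen of a longer chain ending in an amine or a carboxylic acid.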